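The source may hold more compounds than are shown below. What is called first, only, known or untested is meant among the compounds shown, and "the series" means these compounds.

Measured in a functional assay on PC-3 cells (Homo sapiens) for cytotoxicity, read by MTT assay; a lower number here means a stronger inhibitor, a higher number a weaker inhibitor:
- Compound 1 `COc1cccc(CSc2nnc([C@@H](C)c3ccc4cc(OC)ccc4c3)n2-c2ccc(Cl)cc2)c1`: 138000 nM
- Compound 2 `COc1ccc2cc([C@H](C)c3nnc(SCc4ccccc4)n3-c3ccc(Cl)cc3)ccc2c1`: 14200 nM
- Compound 3 `COc1ccc2cc([C@H](C)c3nnc(SCc4ccc(F)cc4)n3-c3ccc(F)cc3)ccc2c1`: <= 400000 nM, a limit and not a number

Of the two actual numbers, the lower belongs to compound 2, at 14200 nM. Compound 4 `COc1ccc2cc([C@H](C)c3nnc(SCc4c(Cl)cccc4Cl)n3-c3ccc(Cl)cc3)ccc2c1` carries 2,6-dichlorophenyl in place of phenyl on a saturated chain carbon bound to a sulfur. Among the measured compounds shown here, one measured step bears on this change: a 9.7-fold lower number from compound 1 to compound 2 (0.99 log units; beyond the scatter), where hydrogen replaces methoxy on an aromatic carbon. That step is modest and lowers the number. For the measured compounds named here, no measured step adds chlorine, so this single precedent is weak. Adding substituents is therefore expected to raise the number modestly in this assay. The estimated step is a 2.5-fold higher number from compound 2 to compound 4 (0.39 log units; beyond the scatter). Compound 4 is expected at 35000 nM, with an estimated range of 8000 nM to 150000 nM.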

Compound 4, half-maximal inhibitory concentration: 34700 nM
Compound 4: the middle estimate sits 1.0-fold (0.00 log units) above what was measured; measured number inside the range.
By their numbers in this assay, from the lowest: compound 2; then compound 4; then compound 1.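

In this assay the phenyl on the saturated chain carbon bound to a sulfur now has a chlorine-bearing comparison: a 2.4-fold higher number from compound 2 to compound 4 (0.39 log units; beyond the scatter) with 2,6-dichlorophenyl, so the position keeps measurable activity at a modest cost. The same group also compares favourably with 3-methoxyphenyl, with a 4.0-fold lower number from compound 1 to compound 4 (0.60 log units; beyond the scatter) so both substituted rings shown sit above unsubstituted phenyl. Among these three compounds, no substituent on this ring lowers the number.

Going by these compounds, whether an amine, a carboxylic acid or a longer chain at this place would lower the number remains open. Nothing shown accounts for the size of these steps.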